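From compound 2 to compound 4: tert-butyl enters

A few compounds are considered here, and "the series" means these few. Any claim that something is new, unique, unknown or untested is made for them only; others in the source may bear on it.

In an ADME assay on HEK-293T cells (Homo sapiens) for cytotoxicity, read by MTT assay, with a stated time of 3 days (on this read-out higher numbers stand for lower toxicity in this test and lower numbers for higher toxicity in this test), three compounds with a shared core have been read so far. Compound 1 (`CC(C)(C)NC(=O)COC(=O)c1ccc([N+](=O)[O-])o1`) gives > 100000 nM as a limit of the assay and not a number. Compound 2 (`O=C(COC(=O)c1ccc([N+](=O)[O-])o1)NCC1CCCO1`) gives > 100000 nM as a limit too. Compound 3 (`O=C(OCC(=O)N(Cc1ccc(O)cc1)CC1CCCO1)c1ccc([N+](=O)[O-])o1`) gives > 100000 nM as a limit as well. Compound 2 therefore stands with no number of its own, and the same holds for the other two.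

Compound 4 (`CC(C)(C)C(=O)COC(=O)c1ccc([N+](=O)[O-])o1`) departs from compound 2 by tert-butyl in place of ((oxolan-2-yl)methyl)amino on a carbonyl carbon with tert-butyl in place of ((oxolan-2-yl)methyl)amino on a carbonyl carbon. Within the data shown here, two measured steps bear on this change. One is a step that the two limits leave unreadable from compound 1 to compound 2 with (oxolan-2-yl)methyl in place of tert-butyl on an amide-type nitrogen. The other is a step that the two limits leave unreadable from compound 2 to compound 3 with 4-hydroxybenzyl in place of hydrogen on an amide-type nitrogen. Neither has a size that can be read, and the whole record comes down to the limit of > 100000 nM in this assay, at which 3 of the 3 values shown sit, with no number yet in hand.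

The limit of compound 2 at > 100000 nM gives no ground for foreseeing a shift beyond the scatter. The expected step is a number no higher from compound 2 to compound 4 (the limit leaves the size open) with neither direction favoured. For compound 4 the estimated value in this assay is 100000 nM with an expected range of 40000 nM to 200000 nM around it.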

Compound 4, half-maximal cytotoxic concentration: > 100000 nM
Compound 4 ended at the assay's limit (the forecaster's own chance of this, stated with the estimate: 70%); the middle value sits exactly at the limit.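

Neither the step from compound 2 to compound 4 nor the step from compound 1 to compound 4 can be read in this assay, and the record remains a single limit: the limit of > 100000 nM in this assay, at which 4 of the 4 values shown sit. The compounds shown leave open whether any of these changes on the shared core shifts the read-out at all.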